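The source may report more compounds than this note shows. Statements on the series, on what has been measured and on what is new or still open speak of the compounds shown alone.

Measured in a functional assay on B16 cells (Mus musculus) for antiproliferative activity, read by MTT assay, with a stated time of 24 h; on this read-out higher numbers stand for weaker inhibition and lower numbers for stronger inhibition:
- compound 1 `C=CCOc1ccc2c(=O)c(-c3cc(OC)c(OC)cc3OC)coc2c1`: 5100 nM
- compound 2 `COc1cc(OC)c(-c2coc3cc(OCc4ccccc4F)ccc3c2=O)cc1OC`: 1610 nM
- compound 3 `COc1cc(OC)c(-c2coc3cc(OCc4cccc(Cl)c4)ccc3c2=O)cc1OC`: 2280 nM

Compound 3 belongs to the lower pair of these numbers. The smallest gap is a 1.4-fold higher number from compound 2 to compound 3 (0.15 log units; within the scatter). The gap on the other side is a 2.2-fold lower number from compound 1 to compound 3 (0.35 log units; beyond the scatter).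

Still unmeasured is compound 4 `COc1cc(OC)c(-c2coc3cc(OCc4ccccc4Br)ccc3c2=O)cc1OC`. Its change from compound 3 is 2-bromophenyl in place of 3-chlorophenyl on a saturated chain carbon bound to an oxygen on an aromatic ring.

The most relevant evidence is the exchange of one halogen-bearing phenyl for another, seen in a 1.4-fold higher number from compound 2 to compound 3 (0.15 log units; within the scatter). The two exchanges of vinyl for such a phenyl, a 3.2-fold lower number from compound 1 to compound 2 (0.50 log units; beyond the scatter) and a 2.2-fold lower number from compound 1 to compound 3 (0.35 log units; beyond the scatter), are modest and bear only loosely, since vinyl is not involved in this change. For the measured compounds named here, no bromine-bearing compound has been measured, so the size of the step rests on these analogies alone.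

No step beyond the scatter is therefore expected in this assay, with a slight lean towards the number of compound 2, which also carries a 2-halophenyl group. The expected step is a 1.2-fold lower number from compound 3 to compound 4 (0.08 log units; within the scatter). The estimate for compound 4 is 1900 nM, with an expected range of 950 nM to 3800 nM.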

Compound 4, half-maximal inhibitory concentration: 8900 nM
Compound 4: the middle estimate sits 4.7-fold (0.67 log units) below what was measured, outside the stated range (above it).
By their numbers in this assay, from the lowest: compounds 2 and 3 (each within the scatter of the next); then compounds 1 and 4 (each within the scatter of the next).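

In this assay, a halogen-bearing phenyl at this place on the saturated chain carbon does not by itself secure the gain over vinyl: a 1.7-fold higher number from compound 1 to compound 4 (0.24 log units; within the scatter), whereas the earlier exchanges of vinyl had both moved beyond the scatter. The identity of the halogen now counts, since two compounds that both carry a 2-halophenyl group separate clearly, with a 5.5-fold higher number from compound 2 to compound 4 (0.74 log units; beyond the scatter), and the exchange of 3-chlorophenyl for 2-bromophenyl also leaves the scatter, with a 3.9-fold higher number from compound 3 to compound 4 (0.59 log units; beyond the scatter), unlike the earlier exchange of one halogen-bearing phenyl for another, a 1.4-fold higher number from compound 2 to compound 3 (0.15 log units; within the scatter). No measurement at hand accounts for this loss.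

The step from compound 3 to compound 4 changes both the halogen and its place on the phenyl ring, so the two contributions cannot be separated; a 2-chlorophenyl or a 3-bromophenyl compound would divide them. As far as these compounds go, how a plain benzyl, a methoxy-bearing phenyl or a chain ending in an amine would read at this place also stays open.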